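From Pyridin-3-yl to Pyridin-2-yl in Compound 1

A few compounds are considered here, and "the series" means these few. Any claim that something is new, unique, unknown or untested is made for them only; others in the source may bear on it.

Compound 1 `Cc1ccc(S(=O)(=O)NC(=O)c2cccnc2)cc1`: 8800 nM
Compound 2 `O=C(NS(=O)(=O)c1ccc(F)cc1)c1cncc(C(=O)NS(=O)(=O)c2ccc(F)cc2)c1`: 1900 nM
Compound 3 `O=C(NS(=O)(=O)c1ccc(Cl)cc1)c1ccncc1`: 8900 nM

All three compounds were tested in a functional assay on RAW264.7 cells (Mus musculus) for inhibition; a higher number here means a weaker inhibitor, a lower number a stronger inhibitor. Compound 1 stands level with compound 3, their numbers lying within the scatter, while compound 2 has a lower number, beyond the scatter. The untested compound 4 `Cc1ccc(S(=O)(=O)NC(=O)c2ccccn2)cc1` differs from compound 1 in one place: pyridin-2-yl in place of pyridin-3-yl on a carbonyl carbon. Among the measured compounds shown here, no measured pair isolates this change, so the data offer no direct guide. No step beyond the scatter is expected in this assay. The estimated step of a 1.1-fold lower number from compound 1 to compound 4 (0.04 log units; within the scatter) is therefore small. Compound 4 is expected at 8000 nM, with an estimated range of 3000 nM to 20000 nM.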

Compound 4, half-maximal inhibitory concentration: 5900 nM
Compound 4: middle estimate off by 1.4-fold (0.13 log units), on the high side; the measured number falls inside the stated range.
By their numbers in this assay, from the lowest: compound 2; then compounds 4, 1 and 3 (each within the scatter of the next).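

In this assay the swap of pyridin-3-yl for pyridin-2-yl on the carbonyl carbon gives a 1.5-fold lower number from compound 1 to compound 4 (0.17 log units; within the scatter) and so stays within the scatter. Among the compounds shown here, this is the first change in the set that can be read in isolation, and it shows that the two pyridine attachments cannot be told apart at this position in this assay. Nothing at hand bears on this result.

Still open, on these data alone, is whether a plain phenyl ring on the same carbonyl carbon would give a number apart from those of compound 1 and compound 4.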